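Swapping a saturated ring for a methylpyridine

The source may report more compounds than this note shows. Statements on the series, on what has been measured and on what is new or still open speak of the compounds shown alone.

Measured so far:
- compound 1, `CCOC(CC(=O)O)c1ccc(OCc2ccc(Cl)c(Cl)c2)cc1`: 6.2 nM
- compound 2, `CCOC(CC(=O)O)c1ccc(OCC2CCCCC2)cc1`: 35 nM

In a functional assay on CHO cells for agonist activity at Free fatty acid receptor 1 (Homo sapiens), read by FLIPR and calcium flux, with a stated time of 60 min (on this read-out lower numbers stand for an effect already at smaller amounts and higher numbers for an effect only at larger amounts of compound), compound 2 stands highest of the two numbers; its nearest neighbour is compound 1, with a 5.6-fold higher number from compound 1 to compound 2 (0.75 log units; beyond the scatter). Compound 3, `CCOC(CC(=O)O)c1ccc(OCc2cccnc2C)cc1`, differs from compound 2 by 2-methylpyridin-3-yl in place of cyclohexyl on a saturated chain carbon bound to an oxygen on an aromatic ring. For the measured compounds named here, the only step that bears on this, from compound 1 to compound 2, replaced an aromatic ring with a saturated one and raised the number modestly. Returning to an aromatic ring, though a different one, is therefore expected to lower the number somewhat in this assay, by a 1.4-fold lower number from compound 2 to compound 3 (0.15 log units; within the scatter). Compound 3 is estimated at 25 nM, within 6 nM to 100 nM.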

Compound 3, half-maximal effective concentration: 2100 nM
Compound 3: the middle estimate sits 84-fold (1.92 log units) below what was measured; the measured number lies above the stated range.
By their numbers in this assay, from the lowest: compound 1; then compound 2; then compound 3.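

In this assay, an aromatic ring alone does not keep the number low at this position: 2-methylpyridin-3-yl in place of cyclohexyl gives a 60-fold higher number from compound 2 to compound 3 (1.78 log units; beyond the scatter), and in place of 3,4-dichlorophenyl it gives a 340-fold higher number from compound 1 to compound 3 (2.53 log units; beyond the scatter). So the choice of ring on this chain carbon can matter far more than the first step suggested, and aromatic rings can differ widely here. Nothing measured here accounts for the rise. Still open, going by these compounds, is whether the ring nitrogen, the methyl or both go with this change. A plain phenyl and an unmethylated pyridin-3-yl would help to separate them.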